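This account rests on a few compounds, and the source may have more. Where it says the series, first, only, none or still open, it means among the compounds named here.

Measured in an assay on Caudate-putamen for displacement of a labelled ligand from Transporter (Macaca mulatta); a lower number here means a stronger inhibitor, a higher number a weaker inhibitor:
Compound 1 `COC(=O)C1=C(c2ccc(Br)cc2)CC2CCC1S2` gives 9.1 nM.
Compound 2 `COC(=O)C1=C(c2ccc(F)c(F)c2)CC2CCC1S2` gives 75 nM.

Of these two numbers, compound 2 stands at the highest; compound 1 lies at a lower number, a gap beyond the usual scatter of this assay. Compound 3 `COC(=O)C1=C(c2ccc(Cl)c(F)c2)CC2CCC1S2` differs from compound 2 by chloro in place of fluoro on an aromatic carbon. For the measured compounds named here, no measured pair isolates this change, so its effect in this assay is not known. A move toward lower numbers, beyond the scatter, is nevertheless expected because compound 1 gives 9.1 nM. For compound 3 the estimate is 18 nM, with a range from 6 nM to 50 nM, which would mean an expected step of a 4.2-fold lower number from compound 2 to compound 3 (0.62 log units; beyond the scatter).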

Compound 3, half-maximal inhibitory concentration: 10 nM
Estimate against measurement, compound 3: 1.8-fold (0.26 log units) above, within the range that was stated.
By their numbers in this assay, from the lowest: compounds 1 and 3 (each within the scatter of the next); then compound 2.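

In this assay, for the compounds shown here, chloro in place of fluoro on this aromatic carbon, ortho to a fluoro group and para to a large group, gives a 7.5-fold lower number from compound 2 to compound 3 (0.88 log units; beyond the scatter) as the first direct reading of this change. The exchange of one heavy atom, with no change in hydrogen-bond donors, acceptors or net charge, is thus enough to move the number beyond the scatter. Nothing measured here accounts for the size of this step.

The compounds shown leave open how a methyl or a methoxy group would fare on this carbon. They also leave open whether the step would persist without the fluoro group.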